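One Added Methyl and the Dose for Compound 4

The source may hold more compounds than are shown below. What is called first, only, known or untested is meant among the compounds shown, and "the series" means these compounds.

Within the data shown here, in a functional assay on the whole organism (Abdomen) with Mus musculus as the target (a higher number here means that more compound is needed for the effect, a lower number that less compound is needed), compound 2 (`Cc1nc(Cc2c[nH]cn2)sc1C`) gives 1.7 mg/kg, the lower of the two numbers measured so far. Compound 1 (`CCCc1nc(Cc2c[nH]cn2)c(CCC)s1`) gives 30 mg/kg. Compound 3 (`CCc1nc(Cc2c[nH]cn2)sc1C`) yields only a limit, > 30 mg/kg.

Compound 4 (`CCc1sc(Cc2c[nH]cn2)nc1C`) departs from compound 2 by methyl in place of hydrogen on a saturated chain carbon bound to an aromatic carbon. This is methyl in place of hydrogen on a saturated chain carbon bound to an aromatic carbon, or methyl to ethyl when cut one bond further out.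

Among the measured compounds shown here, one measured step bears on this change: an at least 17-fold higher number from compound 2 to compound 3 (1.24 log units; beyond the scatter). It is the same kind of change, made on a different methyl of compound 2, and the size of the step is bounded on one side only. A single example at another place is weak support, so a large rise in this assay is expected, though perhaps a smaller one. The expected step is a 7.1-fold higher number from compound 2 to compound 4 (0.85 log units; beyond the scatter). For compound 4 the estimated value is 12 mg/kg, with an expected range from 3 mg/kg to 50 mg/kg.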

Compound 4, dose for half-maximal effect: 2.8 mg/kg
Compound 4: middle estimate off by 4.3-fold (0.63 log units), on the high side; the measured number lies below the stated range.
By their numbers in this assay, from the lowest: compounds 2 and 4 (each within the scatter of the next); then compound 1.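

In this assay, the methyl to ethyl change at this place, on a saturated chain carbon bound to an aromatic carbon, gives a 1.6-fold higher number from compound 2 to compound 4 (0.22 log units; within the scatter). Among these compounds, the one earlier example of this change, made on a different methyl of the same compound, gave an at least 17-fold higher number from compound 2 to compound 3 (1.24 log units; beyond the scatter), so across these two pairs the outcome depends on where the methyl is added. The value of compound 3 is a limit, so that earlier step is bounded on one side only: the limit of > 30 mg/kg in this assay, at which 1 of the 4 values shown sits.

On these data alone, whether a longer chain, an amine or a carboxylic acid would be accepted at this place remains open. Compound 1 differs from compound 2 in more than one place, so it does not settle how a longer chain behaves here.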